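The source may report more compounds than this note shows. Statements on the series, on what has been measured and on what is new or still open speak of the compounds shown alone.

Compound 2, with the structure `COc1cccc(-c2sc(N)c(C(=O)c3ccc(Cl)cc3)c2CC(C)(C)C)c1`, is one of two close relatives measured so far. In an assay on CHO cells for displacement of a labelled ligand from adenosine receptor A3 (Homo sapiens), read by scintillation counting, tested at 10 uM (on this read-out higher numbers stand for more inhibition at the one concentration tested (going by the name of the read-out) and lower numbers for less inhibition), compound 2 gives 1%, and compound 1, with the structure `CC(C)(C)Cc1c(-c2cccc(F)c2F)sc(N)c1C(=O)c1ccc(Cl)cc1`, gives 1%. The step of no change at the digits printed from compound 1 to compound 2 (within the scatter) shows that swapping one aryl group for another on the shared core left the read-out where it was. Compound 3, with the structure `CC(C)c1ccc(-c2sc(N)c(C(=O)c3ccc(Cl)cc3)c2CC(C)(C)C)cc1`, has not yet been measured; it differs from compound 2 as follows: 4-isopropylphenyl in place of 3-methoxyphenyl on an aromatic carbon. Among the measured compounds shown here, the only step that bears on this change is the one from compound 1 to compound 2, and it was flat. Since both measured compounds sit at the bottom of the read-out, compound 3 is expected to stay there too, with a step of a number 1 percentage points higher from compound 2 to compound 3 (within the scatter) that amounts to nothing beyond the scatter. Compound 3 is therefore estimated at 2%, within a range from -6% to 12%.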

Compound 3, a percentage reported as inhibition, at one concentration (the size of the read-out at that concentration, not a potency): 1%
Compound 3: middle estimate off by 1 percentage points, on the high side; measured number inside the range.
By their numbers in this assay, from the lowest: compounds 1, 2 and 3 (each within the scatter of the next).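

In this assay the read-out shows no change at the digits printed from compound 2 to compound 3 (within the scatter), even though 4-isopropylphenyl is made of carbon only and counts no hydrogen-bond acceptors, while the 3-methoxyphenyl it replaces holds an oxygen. The comparison with the difluorinated relative gives no change at the digits printed from compound 1 to compound 3 (within the scatter), so all three aryl groups on this aromatic carbon next to the ring sulfur now sit level at the bottom of the read-out. No measurement at hand offers an explanation for this flat result.

As far as these compounds go, it remains open whether a phenyl ring bearing an amine or a carboxylic acid, or a longer alkyl chain in place of the ring, would lift the number at this position. These compounds also leave open whether replacing the neopentyl group or the (4-chlorophenyl)carbonyl group would move it.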